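Chain swaps leave rat brain inhibition flat

A few compounds are considered here, and "the series" means these few. Any claim that something is new, unique, unknown or untested is made for them only; others in the source may bear on it.

- compound 1 `CCCCCc1ccc(-c2c(C)[nH]c(=O)n2C2CCCCC2)cc1`: 10600 nM
- compound 2 `CCCCCCOc1ccc(-c2c(C)[nH]c(=O)n2C2CCCCC2)cc1`: 8500 nM
- compound 3 `CCCCCCCOc1ccc(-c2c(C)[nH]c(=O)n2C2CCCCC2)cc1`: 11600 nM

All three compounds were read in a functional assay on brain (Rattus norvegicus, strain Wistar) for inhibition (on this read-out higher numbers stand for weaker inhibition and lower numbers for stronger inhibition), and compound 3 stands level with the other two. The record shows a 1.1-fold higher number from compound 1 to compound 3 (0.04 log units; within the scatter), and also a 1.4-fold higher number from compound 2 to compound 3 (0.14 log units; within the scatter). Neither step separates compound 3 from the others.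

The next structure is compound 4 `Cc1[nH]c(=O)n(C2CCCCC2)c1-c1ccc(OCc2ccccc2)cc1`, which keeps the shared core and alters only the chain on the oxygen. The change is phenyl in place of hexyl on a saturated chain carbon bound to an oxygen on an aromatic ring, or heptyloxy to benzyloxy when cut one bond further out.

Within the data shown here, three measured steps bear on this change, all of them in the same chain region. They are a 1.2-fold lower number from compound 1 to compound 2 (0.10 log units; within the scatter), a 1.1-fold higher number from compound 1 to compound 3 (0.04 log units; within the scatter) and a 1.4-fold higher number from compound 2 to compound 3 (0.14 log units; within the scatter). All three stay within the scatter, so these chain changes gave no measurable shift in this assay. None of them places a ring on this chain, however, so the data do not test that feature directly, and the range has to stay wide.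

The expected step is therefore none beyond the scatter, estimated as a 1.2-fold lower number from compound 3 to compound 4 (0.06 log units; within the scatter). For compound 4 the estimated value is 10000 nM, with an expected range from 3500 nM to 28000 nM.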

Compound 4, half-maximal inhibitory concentration: 8300 nM
The estimate for compound 4 lay 1.2-fold (0.08 log units) above the measured number, within the range that was stated.
By their numbers in this assay, from the lowest: compounds 4, 2, 1 and 3 (each within the scatter of the next).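

Placing a ring on the chain, a feature absent from the earlier compounds, still gave no measurable shift in this assay: phenyl in place of hexyl on a saturated chain carbon bound to an oxygen on an aromatic ring gives (a 1.4-fold lower number from compound 3 to compound 4 (0.15 log units; within the scatter)), and phenyl in place of pentyl at the same place gives (a 1.0-fold lower number from compound 2 to compound 4 (0.01 log units; within the scatter)). Swapping the pentyl chain for the benzyloxy group likewise gives (a 1.3-fold lower number from compound 1 to compound 4 (0.11 log units; within the scatter)), so among these four compounds a six-membered aromatic ring of carbon only and the saturated chains cannot be told apart by this read-out. Nothing measured alongside these numbers offers an explanation for this flat response.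

The compounds shown leave open whether an amine or a carboxylic acid in place of the phenyl, or a longer chain carrying the phenyl, would produce a step beyond the scatter. They also leave open whether any change at this position can move the number at all, since every step shown here stays within the scatter and the rest of the shared core remains the same throughout.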